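A few compounds are considered here, and "the series" means these few. Any claim that something is new, unique, unknown or untested is made for them only; others in the source may bear on it.

Measured so far in an ADME assay on Caco-2 cells (Homo sapiens) for permeability, in the apical to basolateral direction; a higher number here means that the compound crosses the layer faster, a lower number that the compound crosses the layer more slowly
- compound 1 `Fc1ccc(Nc2ccc3c(C4CCNCC4)c[nH]c3c2)cc1F` gives 7.1 10^-6 cm/s
- compound 2 `Cn1cc(C2CCNCC2)c2ccc(Nc3ccc(F)c(F)c3)cc21` gives 3 10^-6 cm/s
- compound 3 `Fc1ccc(Nc2ccc3c(C4CCNCC4)c[nH]c3n2)cc1F` gives 14.5 10^-6 cm/s

Compound 1 stands in the middle of these three numbers: compound 3 reads higher and compound 2 reads lower. The next compound to be tested is compound 4 `CN1CCC(c2c[nH]c3cc(Nc4ccc(F)c(F)c4)ccc23)CC1`, which carries one change to compound 1: methyl in place of hydrogen on an amine nitrogen in a ring. In words, a methyl replaces the hydrogen on an amine nitrogen in a ring, turning piperidin-4-yl into 1-methylpiperidin-4-yl.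

Going by the values given here, the one measured step that bears on this change is a 2.4-fold lower number from compound 1 to compound 2 (0.37 log units; beyond the scatter). That step also swaps a hydrogen for a methyl, but on an aromatic nitrogen, so it is only a loose guide. Among the compounds with values here, no measured pair shows this change at the amine nitrogen itself, and the direction in this assay stays open. A step of modest size at most therefore seems reasonable, and none beyond the scatter is the most likely outcome. The expected step is a 1.1-fold higher number from compound 1 to compound 4 (0.02 log units; within the scatter). For compound 4 the estimate is 7.5 10^-6 cm/s, with an expected range from 3 10^-6 cm/s to 16 10^-6 cm/s.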

Compound 4, apparent permeability: 10.4 10^-6 cm/s
Compound 4: the middle estimate sits 1.4-fold (0.14 log units) below what was measured; the range from low to high includes it.
By their numbers in this assay, from the lowest: compound 2; then compounds 1, 4 and 3 (each within the scatter of the next, the first and the last beyond it).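

In this assay, methyl in place of hydrogen on an amine nitrogen in a ring gives a 1.5-fold higher number from compound 1 to compound 4 (0.17 log units; within the scatter), so turning piperidin-4-yl into 1-methylpiperidin-4-yl leaves compound 4 within the ordinary spread of repeat measurements of compound 1. Going by these compounds alone, this is the first direct reading at this nitrogen, and it shows that this position accepts a methyl without a step that can be told apart from that spread. Within the data shown here, the same swap on an aromatic nitrogen gave a 2.4-fold lower number from compound 1 to compound 2 (0.37 log units; beyond the scatter), so in this small set only the step at the aromatic nitrogen lies beyond the scatter, and no measurement offered here gives a reason for the two sites reading differently.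

A methyl is the only group shown on this amine nitrogen, so it remains open what an ethyl, a longer chain or an acetyl group would do there. Going by these compounds, it is also open whether the same methyl would give a similar step on the core of compound 3, which reads differently from the core of compound 1.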